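Shortening the amine tail of a quinone N-oxide core

The source may hold more compounds than are shown below. What is called first, only, known or untested is meant among the compounds shown, and "the series" means these compounds.

Measured compounds:
- compound 1, `CN1CCN(CCCCCCn2c3c(c4ccccc42)C(=O)c2c[n+]([O-])c4ccccc4c2C3=O)CC1`: 2400 nM
- compound 2, `O=C1c2c[n+]([O-])c3ccccc3c2C(=O)c2c1c1ccccc1n2Cc1cn(CC(O)CO)nn1`: 1290 nM
- compound 3, `O=C1c2c[n+]([O-])c3ccccc3c2C(=O)c2c1c1ccccc1n2CCN1CCCC1`: 630 nM

Of the compounds shown here, three built on a shared core have been tested in a functional assay on MDA-MB-231 cells (Homo sapiens) for cytotoxicity, read by MTT assay, with a stated time of 72 h; a higher number here means a weaker inhibitor, a lower number a stronger inhibitor. Compound 1 gives the highest of the three numbers in this assay; its nearest neighbour is compound 2, whose step a 1.9-fold lower number from compound 1 to compound 2 (0.27 log units; within the scatter) is within the scatter, while the step of a 3.8-fold lower number from compound 1 to compound 3 (0.58 log units; beyond the scatter) is beyond it, a modest gain.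

Compound 4, `CN(C)CCCCCn1c2c(c3ccccc31)C(=O)c1c[n+]([O-])c3ccccc3c1C2=O`, is not yet measured. It differs from compound 1 by dimethylamino in place of (4-methylpiperazin-1-yl)methyl on a saturated chain carbon, five bonds along the chain from an aromatic nitrogen. Both measured steps from compound 1 replace the piperazine-bearing tail with something smaller, and both move the number down, one within the scatter and one modestly beyond. Compound 4 keeps a basic amine on a shorter chain, so a small move downward in this assay is expected, likely no larger than the scatter, with a 1.6-fold lower number from compound 1 to compound 4 (0.20 log units; within the scatter). Compound 4 is therefore estimated at 1500 nM in this assay, with a range from 600 nM to 4000 nM.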

Compound 4, half-maximal inhibitory concentration: 240 nM
Compound 4: middle estimate off by 6.3-fold (0.80 log units), on the high side; measured number outside the range, below it.
By their numbers in this assay, from the lowest: compound 4; then compound 3; then compounds 2 and 1 (each within the scatter of the next).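

At this position, on a saturated chain carbon five bonds along the chain from an aromatic nitrogen, dimethylamino in place of (4-methylpiperazin-1-yl)methyl gives a 10-fold lower number from compound 1 to compound 4 (1.00 log units; beyond the scatter) in this assay and so shows that the end of the tail can shift the number without the chain being cut back. The same compound also stands clear of the others, with a 2.6-fold lower number from compound 3 to compound 4 (0.42 log units; beyond the scatter) and a 5.4-fold lower number from compound 2 to compound 4 (0.73 log units; beyond the scatter) in that assay, so a shorter tail alone does not order these numbers, and compound 4 goes against that reading when set beside compound 3. No measurement at hand accounts for these steps.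

The compounds shown leave open how much of the step belongs to the end amine and how much to the chain. From the compounds shown here alone, how a morpholine or a primary amine on the same chain would read also remains open.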